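Swapping methoxy for fluoro on the benzyl amide

The source may hold more compounds than are shown below. What is called first, only, known or untested is meant among the compounds shown, and "the series" means these compounds.

Compounds 1, 2 and 3 share one core and differ only in the group on the amide nitrogen. Compound 1 `O=C(Nc1ccccc1)c1cc(Oc2ccc(/C=C/c3ccccn3)cc2)ccn1` carries a plain phenyl there, compound 2 `COc1ccc(NC(=O)c2cc(Oc3ccc(/C=C/c4ccccn4)cc3)ccn2)cc1` a 4-methoxyphenyl, and compound 3 `COc1ccc(CNC(=O)c2cc(Oc3ccc(/C=C/c4ccccn4)cc3)ccn2)cc1` a 4-methoxybenzyl. In a functional assay on A549 cells (Homo sapiens) for antiproliferative activity, read by CCK-8 assay, with a stated time of 48 h (a lower number here means a stronger inhibitor, a higher number a weaker inhibitor), compound 1 gives 19100 nM, compound 2 gives 20000 nM and compound 3 gives 63600 nM, so compound 3 has the highest number of the three, beyond the scatter from both others, as the steps of a 3.3-fold higher number from compound 1 to compound 3 (0.52 log units; beyond the scatter) and a 3.2-fold higher number from compound 2 to compound 3 (0.50 log units; beyond the scatter) show. Compound 4 `O=C(NCc1ccc(F)cc1)c1cc(Oc2ccc(/C=C/c3ccccn3)cc2)ccn1` keeps the benzyl amide of compound 3 and changes only the substituent on it: fluoro in place of methoxy on an aromatic carbon. Within the data shown here, no measured step involves fluoro, so the closest guide is a 1.0-fold higher number from compound 1 to compound 2 (0.02 log units; within the scatter), which suggests that the substituent at this position matters little. The step of a 1.1-fold lower number from compound 3 to compound 4 (0.03 log units; within the scatter) is therefore expected to stay within the scatter, with no clear direction. Compound 4 is estimated to give 60000 nM, between 25000 nM and 150000 nM.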

Compound 4, half-maximal inhibitory concentration: > 100000 nM
Compound 4: a limit, no number; the forecaster's own chance of this, stated with the estimate: 10%; at least 1.6-fold (0.22 log units) between middle value and limit.
By their numbers in this assay, from the lowest: compounds 1 and 2 (each within the scatter of the next); then compound 3. At a limit, above all of these: compound 4.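

Compound 4 is read in this assay only as a limit, not as a number: the limit of > 100000 nM in this assay, at which 1 of the 4 values shown sits. The step of an at least 1.5-fold higher number from compound 3 to compound 4 (0.19 log units; that floor lies within the scatter) therefore gives only a floor, so fluoro in place of methoxy on the benzyl amide cannot yet be told apart from no change, nor can a larger loss be ruled out. Both benzyl amides sit above the two phenyl-type amides, and compound 4 does so beyond the scatter, with an at least 5.0-fold higher number from compound 2 to compound 4 (0.69 log units; beyond the scatter) and an at least 5.2-fold higher number from compound 1 to compound 4 (0.71 log units; beyond the scatter).

As far as these compounds go, it remains open whether an amine, a carboxylic acid or a plain hydrogen in place of the fluoro on the benzyl ring would bring the number down. From the compounds shown here alone, it is also open whether fluoro on the phenyl amide of compound 1 would behave as methoxy does in compound 2.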